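The source may report more compounds than this note shows. Statements on the series, on what has been measured and on what is new or still open speak of the compounds shown alone.

Compound 1 `O=S(=O)(c1cccc(C(F)(F)F)c1)N1CCc2ccc(-c3cc(F)cc(OC(F)F)c3)cc21`: 0.19 h
Compound 2 `O=C(CC1Cc2ccc(-c3cc(F)cc(OC(F)F)c3)cc2N1S(=O)(=O)c1cccc(C(F)(F)F)c1)N1CCC(O)CC1`: 0.0117 h

In an ADME assay on microsomes from liver (Mus musculus) for metabolic stability, read by LC-MS, using NADPH, with a stated time of 60 min, tested at 1 uM (a lower number here means that the compound disappears faster, a higher number that the compound lasts longer), compound 2 has the lower of the two numbers, at 0.0117 h. Compound 3 `O=C(O)C1CCN(C(=O)CC2Cc3ccc(-c4cc(F)cc(OC(F)F)c4)cc3N2S(=O)(=O)c2cccc(C(F)(F)F)c2)CC1` differs from it only at the end of the side chain: carboxy in place of hydroxy on a saturated ring carbon. This puts carboxy in place of hydroxy on a saturated ring carbon, three ring bonds from the ring nitrogen.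

Within the data shown here, only one measured step bears on this change: a 16-fold lower number from compound 1 to compound 2 (1.21 log units; beyond the scatter), a large step with ((4-hydroxypiperidin-1-yl)carbonyl)methyl in place of hydrogen. It introduced the side chain but did not test this swap, so it is a weak guide. Compound 1 at 0.19 h shows the room above compound 2. A partial recovery is expected, an estimated rise of a 3.4-fold higher number from compound 2 to compound 3 (0.53 log units; beyond the scatter), though its size is uncertain. Compound 3 is expected at 0.04 h, with an estimated range of 0.01 h to 0.2 h.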

Compound 3, half-life: 0.502 h
Compound 3: the middle estimate sits 13-fold (1.10 log units) below what was measured; the whole stated range lies below it.
By their numbers in this assay, from the lowest: compound 2; then compound 1; then compound 3.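

In this assay the end of the side chain turns out to matter a great deal: carboxy in place of hydroxy on the saturated ring carbon gives a 43-fold higher number from compound 2 to compound 3 (1.63 log units; beyond the scatter) in a single swap. The side chain as such therefore does not fix the outcome, since adding it with hydroxy at its end gives a 16-fold lower number from compound 1 to compound 2 (1.21 log units; beyond the scatter) while adding it with carboxy at its end gives a 2.6-fold higher number from compound 1 to compound 3 (0.42 log units; beyond the scatter) and so reverses the direction. Nothing measured here explains this difference between the two end groups.

Going by these compounds, it remains open whether the gain needs carboxy itself or would also appear with a methyl ester, a primary amide or an amine on the same ring carbon. A longer chain between that ring carbon and the carboxylic acid is also untested ground among the compounds shown.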